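The compounds below may be only part of what the source reports. "The series", "measured", "known", "first", "only" and "open" are said of these compounds alone.

Compound 2 `CCCCCCCCCCCN1NN=C(NC(=O)Nc2c(C(C)C)cccc2C(C)C)N1` gives 9 nM in an assay on microsomes from intestine for inhibition of acyl-CoA:cholesterol acyltransferase (Oryctolagus cuniculus); a higher number here means a weaker inhibitor, a lower number a stronger inhibitor. Compound 1 `CCCCCCCCCN1NN=C(NC(=O)Nc2c(C(C)C)cccc2C(C)C)N1` shares its core and differs from it in one place, (hydrogen in place of ethyl on a saturated chain carbon, nine bonds along the chain from an amine nitrogen in a ring), and in this assay compound 1 gives 31 nM. Within the data shown here, the step of a 3.4-fold higher number from compound 2 to compound 1 (0.54 log units; beyond the scatter) is the only measured example of this change among the four compounds described here.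

Compound 3 `CCCCCCCCCCCc1nnc(NC(=O)Nc2c(C(C)C)cccc2C(C)C)s1` carries a different core; the difference between the core of compound 3 and the core of compound 2 is not broken down here. In this assay compound 3 gives 390 nM, the highest of the three measured numbers and clearly weaker than compound 1 and compound 2.

Compound 4 `CCCCCCCCCc1nnc(NC(=O)Nc2c(C(C)C)cccc2C(C)C)s1` has not been measured. It is made from compound 3 by hydrogen in place of ethyl on a saturated chain carbon, nine bonds along the chain from an aromatic carbon. The place is not the same word for word as in the step from compound 2 to compound 1: there the saturated chain carbon lies nine bonds along the chain from an amine nitrogen in a ring, here nine bonds along the chain from an aromatic carbon. It is therefore the same kind of change, applied on a different core, rather than the same change.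

Since the shortening of the chain on the core of compound 2 was worth a 3.4-fold higher number from compound 2 to compound 1 (0.54 log units; beyond the scatter), a step of about the same size is expected for compound 4, a 3.1-fold higher number from compound 3 to compound 4 (0.49 log units; beyond the scatter), because compound 3 starts from 390 nM. Among the measured compounds shown here, with only one prior example of the change, and on another core, the range is kept wide. Compound 4 is therefore estimated at 1200 nM in this assay, expected between 400 nM and 4000 nM.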

Compound 4, half-maximal inhibitory concentration: 150 nM
Beside the measured number, compound 4's estimate is 8.0-fold (0.90 log units) above it; the whole stated range lies above it.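

In this assay, putting hydrogen in place of ethyl on the saturated chain carbon, nine bonds along the chain from an aromatic carbon, gives a 2.6-fold lower number from compound 3 to compound 4 (0.41 log units; beyond the scatter), so on this core the shorter chain goes with the stronger inhibitor. The same kind of change went the opposite way on the core of compound 2, which shows that in these four compounds neither its size nor its direction carries from one core to the other: the same change on two cores in this assay, a 3.4-fold higher number (0.54 log units; beyond the scatter) from compound 2 to compound 1 and a 2.6-fold lower number (0.41 log units; beyond the scatter) from compound 3 to compound 4, 9.0-fold (0.95 log units) apart, beyond the scatter of two such steps

What this does not show is which feature of the two cores lies behind the difference, and with a single pair on each core it cannot be said whether the reversal is a general feature of the series or holds only for these particular chains.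

The compounds shown leave open how a longer chain, or a chain shorter than those in compound 1 and compound 4, would behave on either core, and so whether each core has its own best chain length. They also leave open what would happen on either core if an amine or a carboxylic acid were carried on the chain.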